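The source may report more compounds than this note shows. Statements on the series, on what has been measured and on what is new or still open speak of the compounds shown alone.

Of the compounds shown here, two built on a shared core have been measured in a physicochemical assay for lipophilicity, in phosphate buffer, measured as octanol-water partition, with a stated time of 24 h; a lower number here means a more polar compound, a higher number a more lipophilic compound. Compound 1 `O=C(CN1C(=O)c2ccccc2C1=O)NN1C(=O)CSC1c1ccco1` gives 1.13. Compound 2 `O=C(CN1C(=O)c2ccccc2C1=O)NN1C(=O)CSC1c1cccs1` gives 2.15, the higher of the two numbers. Compound 3 `O=C(CN1C(=O)c2ccccc2C1=O)NN1C(=O)CSC1c1ccc(Cl)cc1Cl` differs from compound 2 in one place: 2,4-dichlorophenyl in place of thiophen-2-yl on a saturated ring carbon. Going by the values given here, the only step that bears on this change is a number 1.02 log units higher from compound 1 to compound 2 (beyond the scatter), which also arose from exchanging the ring at that saturated ring carbon. Because a number 1.02 log units higher from compound 1 to compound 2 (beyond the scatter) was large, and the new change replaces more atoms and removes the hydrogen-bond acceptor, a rise in this assay at least as large is expected, a number 1.30 log units higher from compound 2 to compound 3 (beyond the scatter). Compound 3 is therefore estimated at 3.45, between 2.9 and 4.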

Compound 3, partition coefficient: 2.54
For compound 3 the middle estimate is 0.91 log units above the measured one; the whole stated range lies above it.
By their numbers in this assay, from the lowest: compound 1; then compound 2; then compound 3.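

In this assay, this saturated ring carbon accepts a six-membered aromatic ring of carbon only in place of thiophen-2-yl, and the number still rises: a number 0.39 log units higher from compound 2 to compound 3 (beyond the scatter). That modest step is smaller than the large one between the two five-membered rings, a number 1.02 log units higher from compound 1 to compound 2 (beyond the scatter), although 2,4-dichlorophenyl stands highest of the three, with a number 1.41 log units higher from compound 1 to compound 3 (beyond the scatter). Nothing available explains the sizes of these steps. Still open, going by these compounds, is how a plain phenyl ring, or one carrying a single chlorine, would read here. On these data alone, an amine or a carboxylic acid on the ring is equally open.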